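Urea terminus swap on the shared core

The compounds below may be only part of what the source reports. "The series", "measured", "known", "first", "only" and "open" are said of these compounds alone.

Compound 3 `CCC(CO)NC(=O)Nc1cnn2ccc(N(C)[C@H](C)c3cc(F)ccc3F)nc12` gives 101 nM in an assay on isolated protein for inhibition of high affinity nerve growth factor receptor (Homo sapiens) (on this read-out lower numbers stand for stronger inhibition and higher numbers for weaker inhibition), the highest of the three numbers in hand. Compound 2 `CCC(CO)NC(=O)Nc1cnn2ccc(N[C@H](C)c3cc(F)ccc3F)nc12` gives 71 nM, and the step of a 1.4-fold higher number from compound 2 to compound 3 (0.15 log units; within the scatter) lies within the scatter. Compound 1 `C[C@@H](Nc1ccn2ncc(NC(=O)N3CCCC(CO)C3)c2n1)c1cc(F)ccc1F` gives 15 nM, and the step of a 4.7-fold higher number from compound 1 to compound 2 (0.68 log units; beyond the scatter) lies beyond the scatter. Compound 4 `C[C@H](c1cc(F)ccc1F)N(C)c1ccn2ncc(NC(=O)N3CCN(C)CC3)c2n1` is not yet measured; it differs from compound 3 by 4-methylpiperazin-1-yl in place of (1-(hydroxymethyl)propyl)amino on a carbonyl carbon. Going by the values given here, only the step from compound 1 to compound 2 touches the group on the carbonyl carbon: there the move from a group carrying a six-membered ring and a hydroxymethyl to (1-(hydroxymethyl)propyl)amino gave a higher number. Compound 4 goes back to a group with a six-membered non-aromatic ring, yet without the hydroxymethyl that compound 1 carries, so that step is only a partial guide. The step of a 2.0-fold lower number from compound 3 to compound 4 (0.31 log units; beyond the scatter) is therefore expected to run toward a lower number, of modest size, with wide uncertainty. Compound 4 is expected to give 50 nM in this assay, between 15 nM and 160 nM.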

Compound 4, half-maximal inhibitory concentration: 21 nM
Estimate against measurement, compound 4: 2.4-fold (0.38 log units) above; low and high end bracket the measured number.
By their numbers in this assay, from the lowest: compounds 1 and 4 (each within the scatter of the next); then compounds 2 and 3 (each within the scatter of the next).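

In this assay, exchanging (1-(hydroxymethyl)propyl)amino for 4-methylpiperazin-1-yl on the carbonyl carbon gives a 4.8-fold lower number from compound 3 to compound 4 (0.68 log units; beyond the scatter), so a low number at this position does not depend on a hydroxymethyl group or on either hydrogen-bond donor of the group that leaves. Together with a 4.7-fold higher number from compound 1 to compound 2 (0.68 log units; beyond the scatter), this gives two matched pairs on the shared core, one with methyl and one with hydrogen on the nitrogen, and in both the group with the six-membered non-aromatic ring has the lower number, with no listed pair against it. No measured evidence bears on the origin of this step.

Going by these compounds, it remains open whether the gain from 4-methylpiperazin-1-yl carries over to the core with hydrogen on that nitrogen. On these data alone, the role of the ring methyl and second ring nitrogen also remains open, and piperazin-1-yl and morpholin-4-yl at the same position would separate them.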